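A few compounds are considered here, and "the series" means these few. Any claim that something is new, unique, unknown or untested is made for them only; others in the source may bear on it.

Compound 1, `CCCC[C@@](C)(OC)[C@H](O)/C=C/C1[C@H](O)C[C@H](O)[C@@H]1C/C=C\CCCC(=O)OC`, gives 1.5 mg/kg in a functional assay on the whole organism (stomach) with Rattus norvegicus as the target; a lower number here means that less compound is needed, a higher number that more compound is needed for the effect.
Compound 2, `CCCC[C@@](C)(OC)[C@H](O)/C=C/C1[C@H](O)CC(=O)[C@@H]1CCCCCCC(=O)OC`, gives 0.0045 mg/kg in this assay.

Among the measured compounds shown here, of the two compounds measured so far, compound 1 stands at the higher number, and the gap to compound 2 is far beyond the usual scatter of repeated measurements, so compound 2 clearly needs less material for the same effect. Compound 2 differs from compound 1 in several places at once, so its number says nothing direct about any single change.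

Compound 3, `CCCC[C@](C)(OC)[C@@H](O)/C=C/C1[C@H](O)C[C@H](O)[C@@H]1C/C=C\CCCC(=O)OC`, is the next compound to be tested. Compared with compound 1 it holds the same atoms and bonds; the only difference is this: the two compounds have the same atoms and bonds; at least one stereo element is drawn with a configuration in one of them and without one in the other: 2 of 8 stereo elements differ; a stereocentre at a saturated chain carbon is drawn R in compound 1 and S in compound 3; a stereocentre at a saturated chain carbon is drawn R in compound 1 and S in compound 3. Nothing in the data pairs two measured compounds that differ only in the drawing of a stereocentre, so there is no shown step to lean on. Changes of this kind often move the number noticeably, and in either direction, so the expected step of a 3.3-fold higher number from compound 1 to compound 3 (0.52 log units; beyond the scatter) is a guess toward a somewhat higher number with wide uncertainty. For compound 3 the estimate is 5 mg/kg, with a range from 0.8 mg/kg to 30 mg/kg.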

Compound 3, dose for 50% inhibition: > 4 mg/kg
Compound 3: only a limit was reported; the forecaster's own chance of this, stated with the estimate: 10%; the middle value lies beyond the limit too.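

In this assay, among the compounds shown here, turning two stereocentres at saturated chain carbons from R to S, with every atom and bond kept, gives an at least 2.6-fold higher number from compound 1 to compound 3 (0.42 log units; beyond the scatter), so configuration at these places alone moves the number, something no earlier pair could show. Going by these compounds, for compound 3 the reported figure is a limit rather than a number, so the true size of the step stays unknown because the reading stops there: the limit of > 4 mg/kg in this assay, at which 1 of the 3 values shown sits. The comparison also carries a caveat about how the two structures are drawn, which limits how exactly the step can be tied to specific configurations: the fact that one of compounds 1 and 3 is drawn with a defined configuration and the other without, at the place where they differ.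

The two stereocentres change together, so the compounds shown do not tell whether one of them alone accounts for the step or both contribute. Also open, on these data alone, is how a carboxylic acid in place of the methyl ester would read in this assay with either configuration, and whether the step would keep its direction with that group present.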